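Methoxy for Fluoro at a Second Site of the Shared Core

This account rests on a few compounds, and the source may have more. Where it says the series, first, only, none or still open, it means among the compounds named here.

Compound 1 `COc1ccc(C(=O)N2CCN(CC(=O)N3CCN(CCCc4c[nH]c5ccccc45)CC3)CC2)cc1`: in an ADME assay on HEK293 cells (Homo sapiens) for cytotoxicity, read by MTT assay, with a stated time of 72 h (on this read-out higher numbers stand for weaker inhibition and lower numbers for stronger inhibition), compound 1 gives 156000 nM
Compound 2 `O=C(CN1CCN(C(=O)c2ccc(F)cc2)CC1)N1CCN(CCCc2c[nH]c3ccccc23)CC1`: in this assay compound 2 gives 141000 nM
Compound 3 `O=C(CN1CCN(C(=O)c2ccccc2)CC1)N1CCN(CCCc2c[nH]c3ccc(F)cc23)CC1`: in this assay compound 3 gives 148000 nM

The three measured compounds sit close together in this assay. Compound 3 and compound 2 are built from the same atoms joined differently; the difference between the two cores is not broken down here, and their two values lie within the scatter of each other.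

One change is seen once among the measured compounds: from compound 2 to compound 1, (methoxy in place of fluoro on an aromatic carbon). That step reads a 1.1-fold higher number from compound 2 to compound 1 (0.04 log units; within the scatter).

Compound 4 `COc1ccc2[nH]cc(CCCN3CCN(C(=O)CN4CCN(C(=O)c5ccccc5)CC4)CC3)c2c1` carries the same kind of change relative to compound 3: methoxy in place of fluoro on an aromatic carbon. The place is not the same, however. In compound 1 the methoxy sits on a six-membered aromatic ring of carbon only, para to a large group; in compound 4 it sits on a six-membered aromatic ring of carbon only that is part of a fused or bridged system of two rings, meta to a fused ring and para to a fused ring.

Because a 1.1-fold higher number from compound 2 to compound 1 (0.04 log units; within the scatter) stayed within the scatter, compound 4 is expected to show a step of a 1.0-fold higher number from compound 3 to compound 4 (0.02 log units; within the scatter) in this assay. The estimate for compound 4 in this assay is 155000 nM, expected to fall between 90000 nM and 260000 nM.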

Compound 4, half-maximal inhibitory concentration: > 200000 nM
Compound 4 was reported as a limit; the forecaster's own chance of this, stated with the estimate: 15%; middle value at least 1.2-fold (0.11 log units) away from the limit.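

In this assay, compound 4 is reported only as a limit, > 200000 nM, and not as a number. At the second site, the change from 5-fluoro-1H-indol-3-yl to 5-methoxy-1H-indol-3-yl therefore gives only a floor for the step, an at least 1.3-fold higher number from compound 3 to compound 4 (0.13 log units; that floor lies within the scatter), and this floor does not show that the change had any effect beyond ordinary repeat variation. The series thus shows that methoxy for fluoro gave no step beyond the scatter on either core as far as the numbers can be read, but it does not show that the change carries over from one core to the other with the same size, because the second step has no upper bound: the same change on two cores in this assay, a 1.1-fold higher number (0.04 log units; within the scatter) from compound 2 to compound 1 and an at least 1.3-fold higher number (0.13 log units; that floor lies within the scatter) from compound 3 to compound 4; the limit leaves it open whether they differ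

From the compounds shown here alone, how far the true value of compound 4 lies past its limit stays open, and so does whether the step on this core is larger than the one on the other core, with the reading resting on a single compound at the limit: the limit of > 200000 nM in this assay, at which 1 of the 4 values shown sits. Also open is how a chloro or a hydroxyl group on the same aromatic carbon, or a longer chain in place of the propyl link to the ring system, would read in this assay.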